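This account rests on a few compounds, and the source may have more. Where it says the series, first, only, none or still open, it means among the compounds named here.

In a functional assay on COLO 205 cells (Homo sapiens) for inhibition, read by sulforhodamine B assay (on this read-out lower numbers stand for stronger inhibition of growth and higher numbers for weaker inhibition of growth), compound 1 (`Cc1ccc2[nH]c(-c3ccc(-c4ccc(-c5cccc(Cl)c5)cc4)cc3)nc2c1`) gives 2780 nM, the lowest of the three numbers in hand. Compound 3 (`Oc1cccc2[nH]c(-c3ccc(-c4ccc(-c5ccc(OC(F)(F)F)cc5)cc4)cc3)nc12`) gives 8320 nM and compound 2 (`Fc1ccc(-c2ccc(-c3ccc(-c4nc5ccccc5[nH]4)cc3)cc2)cc1`) gives 100000 nM, both beyond the scatter from compound 1. Compound 4 (`Cc1ccc2[nH]c(-c3ccc(-c4ccc(-c5ccc(O)cc5)cc4)cc3)nc2c1`) is unmeasured. It has 4-hydroxyphenyl in place of 3-chlorophenyl on an aromatic carbon of the core of compound 1 (4-hydroxyphenyl in place of 3-chlorophenyl on an aromatic carbon). Among the compounds with values here, no measured pair isolates this change. Weaker inhibition of growth, beyond the scatter, is expected, since compound 1 at 2780 nM already holds the lowest number. The expected step is a 3.6-fold higher number from compound 1 to compound 4 (0.56 log units; beyond the scatter). For compound 4 the estimate is 10000 nM, with an expected range of 2500 nM to 50000 nM.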

Compound 4, concentration for 50% growth inhibition: 100000 nM
Beside the measured number, compound 4's estimate is 10-fold (1.00 log units) below it; measured number above the stated range.
By their numbers in this assay, from the lowest: compound 1; then compound 3; then compounds 2 and 4 (each within the scatter of the next).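

Within the data shown here, this is the only single-change step, and it shows that this position, on an aromatic carbon para to a large group, is sensitive to its substituent: in this assay, 4-hydroxyphenyl in place of 3-chlorophenyl gives a 36-fold higher number from compound 1 to compound 4 (1.56 log units; beyond the scatter). The two groups are equal in heavy atoms, so the step does not come with a change in that count. Nothing in hand explains the step.

The swap changes both substituent and place on the ring, so the two remain unseparated. 3-Hydroxyphenyl, 4-chlorophenyl and 4-aminophenyl would each bear on this question.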